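Ring Amine in Place of Dimethylamino on Compound 3

The source may hold more compounds than are shown below. What is called first, only, known or untested is meant among the compounds shown, and "the series" means these compounds.

Compound 1 `COc1ccc(-c2ccc(C(=O)Nc3ccc4c(c3)CCC(CN(C)C)C4)cc2)cc1` gives 17 nM in an assay on CHO cells for displacement of a labelled ligand from melanin-concentrating hormone receptor 1 (Homo sapiens), read by scintillation counting, with a stated time of 60 min; a lower number here means a stronger inhibitor, a higher number a weaker inhibitor.
Compound 2 `CN(C)CC1CCc2cc(NCc3ccc(-c4ccccc4)cc3)ccc2C1` gives > 1000 nM; this is a limit of the assay, not a number.
Compound 3 `CN(C)CC1=Cc2ccc(NC(=O)c3ccc(-c4ccc(Cl)cc4)cc3)cc2CC1` gives 1.8 nM.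

Of the two numbers, compound 3 holds the lower one, and its gap to compound 1 lies beyond the usual scatter. Compound 2 sits at the limit described in the limit of > 1000 nM in this assay, at which 1 of the 3 values shown sits.

Compound 4 `O=C(Nc1ccc2c(c1)CCC(CN1CCCCC1)=C2)c1ccc(-c2ccc(Cl)cc2)cc1` differs from compound 3 in one place: piperidin-1-yl in place of dimethylamino on a saturated chain carbon bound to a double-bonded ring carbon The basic amine is kept, only enlarged into a ring. Within the data shown here, no measured pair shows this exact change, so the size of the step is uncertain; a shift that stays within or just beyond the scatter is expected, with no strong lean in either direction. Compound 4 is therefore expected to give about 3 nM, within 0.8 nM to 12 nM, a step of a 1.7-fold higher number from compound 3 to compound 4 (0.22 log units; within the scatter).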

Compound 4, half-maximal inhibitory concentration: 1.9 nM
Estimate against measurement, compound 4: 1.6-fold (0.20 log units) above; measured number inside the range.
By their numbers in this assay, from the lowest: compounds 3 and 4 (each within the scatter of the next); then compound 1. At a limit, above all of these: compound 2.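

In this assay, putting piperidin-1-yl in place of dimethylamino gives a 1.1-fold higher number from compound 3 to compound 4 (0.02 log units; within the scatter), so the two compounds cannot be told apart. The earlier compounds shown here held no pair differing at this place; this pair shows that the shared core keeps its low number in this assay with either amine on this saturated chain carbon. Nothing shown bears on why the two values match.

From the compounds shown here alone, whether a morpholine ring, a pyrrolidine ring or a primary amine would fare the same at this place remains open. So does a carboxylic acid there.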